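Pyrazinyl in place of pyridinyl on the saturated ring carbon

The compounds below may be only part of what the source reports. "The series", "measured", "known", "first", "only" and "open" are said of these compounds alone.

Compound 1 `COc1cc(C(F)(F)F)cc(SC)c1C(=O)NC1(c2ccccc2)CCCN(C)C1` in an assay on cells for inhibition of sodium- and chloride-dependent glycine transporter 1 (Homo sapiens) (a higher number here means that more compound is needed for the effect, a lower number that less compound is needed), gives 24 nM. In this assay, within the data shown here, compound 2 `COc1cc(C(F)(F)F)cc(SC)c1C(=O)NC1(c2cccnc2)CCCN(C)C1` gives 54 nM, the highest of the two numbers so far; the nearest is compound 1, and the step of a 2.3-fold higher number from compound 1 to compound 2 (0.35 log units; beyond the scatter) lies beyond the scatter. Compound 3 `COc1cc(C(F)(F)F)cc(SC)c1C(=O)NC1(c2cnccn2)CCCN(C)C1` differs from compound 2 by pyrazin-2-yl in place of pyridin-3-yl on a saturated ring carbon. Among the measured compounds shown here, only one measured step bears on this change, a 2.3-fold higher number from compound 1 to compound 2 (0.35 log units; beyond the scatter), where one ring nitrogen entered on the same saturated ring carbon. A second ring nitrogen is therefore expected to raise this assay further, by about a 2.0-fold higher number from compound 2 to compound 3 (0.31 log units; beyond the scatter). Compound 3 is estimated at 110 nM, within 45 nM to 300 nM.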

Compound 3, half-maximal effective concentration: 1670 nM
Estimate against measurement, compound 3: 15-fold (1.18 log units) below, and the stated range ends below it.
By their numbers in this assay, from the lowest: compound 1; then compound 2; then compound 3.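

At this saturated ring carbon, ring nitrogens do not add up evenly: in this assay the change to pyrazin-2-yl gives a 31-fold higher number from compound 2 to compound 3 (1.49 log units; beyond the scatter) whereas the first ring nitrogen gave a 2.3-fold higher number from compound 1 to compound 2 (0.35 log units; beyond the scatter) only. Measured against phenyl, pyrazin-2-yl gives a 70-fold higher number from compound 1 to compound 3 (1.84 log units; beyond the scatter) so this position tolerates pyridin-3-yl far better than pyrazin-2-yl. Nothing available explains the size of this step. From the compounds shown here alone, whether the number of ring nitrogens or their placement matters remains open; pyridin-2-yl and pyrimidin-5-yl on the same carbon would help separate the two.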